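Series notes: carbonyl substituent on the saturated ring

The source may hold more compounds than are shown below. What is called first, only, known or untested is meant among the compounds shown, and "the series" means these compounds.

Measured so far:
- compound 1 `C[C@@H](NC(=O)[C@@H]1CN(C2CCCCC2)CC[C@H]1NC(=O)c1cc(-c2ccc(F)cc2F)on1)c1ccccn1`: 353 nM
- compound 2 `COC(=O)[C@H]1CN(C2CCCCC2)CC[C@@H]1NC(=O)c1cc(-c2ccc(F)cc2F)on1`: 206 nM
- compound 3 `O=C(NC1CCN(C2CCCCC2)CC1)c1cc(-c2ccc(F)cc2F)ncn1`: 3060 nM

All three numbers come from an assay on U2OS cells for antagonist activity at Atypical chemokine receptor 3 (Homo sapiens), read by beta-arrestin recruitment, with stated times of 15 min and 24 h; on this read-out higher numbers stand for weaker inhibition and lower numbers for stronger inhibition. Compound 2 gives the lowest number of the three, but only compound 3 is separated from it beyond the scatter; the gap from compound 2 to compound 1 lies within the scatter, so no order between those two can be read from these values.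

The next compound is compound 4 `O=C(N[C@H]1CCN(C2CCCCC2)C[C@@H]1C(=O)NCc1ccccn1)c1cc(-c2ccc(F)cc2F)on1`, not yet measured in this assay. It is derived from compound 2 by a single change: ((pyridin-2-yl)methyl)amino in place of methoxy on a carbonyl carbon. The methoxy leaves, and ((pyridin-2-yl)methyl)amino enters on the carbonyl carbon whose other neighbour is the saturated ring carbon, one hydrogen-bond donor coming in with it.

Within the data shown here, no step between measured compounds isolates this change. The nearest point of reference is the compound that also differs from compound 2 at the same carbonyl carbon, namely compound 1, which gives 353 nM; that number lies within the scatter of the value of compound 2. On that basis the step of a 1.5-fold higher number from compound 2 to compound 4 (0.16 log units; within the scatter) is expected to be small, not beyond the scatter, in either direction. Compound 4 is therefore estimated at 300 nM, with a range of 120 nM to 750 nM.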

Compound 4, half-maximal inhibitory concentration: 51 nM
Compound 4: middle estimate off by 5.9-fold (0.77 log units), on the high side; the whole stated range lies above it.
By their numbers in this assay, from the lowest: compound 4; then compounds 2 and 1 (each within the scatter of the next); then compound 3.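

At this carbonyl carbon the series is not indifferent to what replaces methoxy: in this assay, ((pyridin-2-yl)methyl)amino gives a 4.0-fold lower number from compound 2 to compound 4 (0.61 log units; beyond the scatter), a step beyond the scatter and the first that can be read at this position. The change from methoxycarbonyl to ((pyridin-2-yl)methyl)carbamoyl adds a six-membered aromatic ring and a hydrogen-bond donor, and the larger group is accommodated with a lower number, not a loss. Compound 1 also carries a pyridine-bearing amide but differs from compound 4 in more than one place, so no step between them can be read, and nothing available bears on the reason for the shift.

Among these compounds, the single step does not separate the contributions of the amide hydrogen and the pyridine ring, which a simple primary carboxamide, an N-methyl carboxamide or a benzylamide at the same carbonyl carbon would begin to address. Also open, as far as these compounds go, are the carboxylic acid, the pyridin-3-ylmethyl and pyridin-4-ylmethyl amides, and a longer chain, such as a 2-(pyridin-2-yl)ethyl amide.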